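Branch Position in the Acid Chain of the Shared Core

The source may hold more compounds than are shown below. What is called first, only, known or untested is meant among the compounds shown, and "the series" means these compounds.

Compound 2 `CC(CCCC(=O)O)c1cccc(OCc2ccc3ccccc3n2)c1` carries its acid chain with the methyl branch on the carbon joined to the aromatic ring. In an assay on membranes from lung (Cavia porcellus) for binding affinity to cysteinyl leukotriene receptor (Homo sapiens) (a lower number here means a stronger inhibitor, a higher number a weaker inhibitor), compound 2 gives 90 nM, the highest of the three numbers in hand. Compound 3 `O=C(O)CC1(CCc2ccc(OCc3ccc4ccccc4n3)cc2)CCCC1` gives 51 nM in this assay; this value and that of compound 2 lie within the scatter of each other and cannot be ordered. Compound 1 `CCCC(CCc1nnn[nH]1)Cc1cccc(OCc2ccc3ccccc3n2)c1`, which has a tetrazole in place of the acid and a methylene between ring and branch, gives 11 nM in this assay, a number beyond the scatter below that of compound 2.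

Compound 4 `CC(CCC(=O)O)Cc1cccc(OCc2ccc3ccccc3n2)c1` keeps every atom of compound 2 but joins them differently: 4-carboxy-2-methylbutyl in place of 4-carboxy-1-methylbutyl on an aromatic carbon. The chain thus reaches the ring through a methylene, as it does in compound 1. Among the measured compounds shown here, no measured pair isolates this change, so its size cannot be read from the data; the only pointer is compound 1, whose value of 11 nM stands with the methylene-linked arrangement.

Compound 4 is expected to give about 45 nM in this assay, with a range of 15 nM to 140 nM. The estimated step of a 2.0-fold lower number from compound 2 to compound 4 (0.30 log units; within the scatter) points to a lower number, of a size near the edge of the scatter.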

Compound 4, inhibition constant: 140 nM
Estimate against measurement, compound 4: 3.1-fold (0.49 log units) below; the range from low to high includes it.
By their numbers in this assay, from the lowest: compound 1; then compounds 3, 2 and 4 (each within the scatter of the next, the first and the last beyond it).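

In this assay the series now has its first step that changes one place only: 4-carboxy-2-methylbutyl in place of 4-carboxy-1-methylbutyl on an aromatic carbon gives a 1.6-fold higher number from compound 2 to compound 4 (0.19 log units; within the scatter), so moving the methyl branch along the chain, with the atoms unchanged, produces no difference that can be told from the scatter, and the two compounds cannot be ordered. Among the compounds shown here, the methylene link to the ring, the feature compound 4 shares with compound 1, therefore brings no number beyond the scatter below that of compound 2 while the carboxylic acid stays in place, and the pointer drawn from compound 1 finds no support in this step. Nothing at hand speaks to the reason for this outcome.

Still open, on these data alone, is what the methyl branch itself contributes at either carbon, which an unbranched chain, an ethyl branch or a gem-dimethyl group on the same chain would address. Also open, as far as these compounds go, is whether a longer chain, or a tetrazole on the chain of compound 4, would move the number beyond the scatter.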